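Compound 3: 4-chlorophenyl in place of isopropyl

This account rests on a few compounds, and the source may have more. Where it says the series, first, only, none or still open, it means among the compounds named here.

In a functional assay on HepG2 cells (Homo sapiens) for antiproliferative activity, read by MTT assay, with a stated time of 72 h (a higher number here means a weaker inhibitor, a lower number a stronger inhibitor), compound 1 (`COc1cccc(N2C(=O)COc3ccc(-c4cccc(NS(=O)(=O)c5ccc(F)cc5)c4)cc32)c1`) gives > 40000 nM, a limit of the assay. Compound 2 (`CC(C)N1C(=O)COc2ccc(-c3cccc(NS(=O)(=O)c4ccc(F)cc4)c3)cc21`) gives > 40000 nM, also a limit. Compound 2 therefore stands at the limit of > 40000 nM in this assay, at which 2 of the 2 values shown sit. For the measured compounds named here, the only measured step bearing on the next change is a step that the two limits leave unreadable from compound 1 to compound 2. Compound 3 (`O=C1COc2ccc(-c3cccc(NS(=O)(=O)c4ccc(F)cc4)c3)cc2N1c1ccc(Cl)cc1`) differs from compound 2 as follows: 4-chlorophenyl in place of isopropyl on an amide-type nitrogen in a ring. With 3-methoxyphenyl on that nitrogen, compound 1 sits at the limit of > 40000 nM, so no step beyond the scatter is expected in this assay. The estimated step is a number no higher from compound 2 to compound 3 (the limit leaves the size open). The expected value for compound 3 is 40000 nM, with an estimated range of 15000 nM to 80000 nM.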

Compound 3, half-maximal inhibitory concentration: 27800 nM
Estimate against measurement, compound 3: 1.4-fold (0.16 log units) above; low and high end bracket the measured number.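

With 4-chlorophenyl on the amide-type nitrogen in a ring, this assay gives a reading at this position that is a number rather than a limit, as compound 3 gives 27800 nM. Replacing isopropyl gives an at least 1.4-fold lower number from compound 2 to compound 3 (0.15 log units; that floor lies within the scatter), and replacing 3-methoxyphenyl gives an at least 1.4-fold lower number from compound 1 to compound 3 (0.15 log units; that floor lies within the scatter). The other two compounds stay at a limit of the assay: the limit of > 40000 nM in this assay, at which 2 of the 3 values shown sit.

Going by these compounds, the true size of both steps stays open, since each rests on a limit. Also open, on these data alone, is whether the chlorine matters here, and how a 4-fluorophenyl or a longer chain ending in an amine would read on that nitrogen.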